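A few compounds are considered here, and "the series" means these few. Any claim that something is new, unique, unknown or untested is made for them only; others in the source may bear on it.

Measured compounds in this set:
Compound 1, `CCOC(=O)c1cc(-c2cccc(OCc3cccc(OC(F)(F)F)c3)c2)on1`: 101000 nM
Compound 2, `CCOC(=O)c1cc(-c2cccc(OCc3cccc(OC)c3)c2)on1`: > 128000 nM
Compound 3, `CCOC(=O)c1cc(-c2cccc(OCc3ccc(C(F)(F)F)cc3)c2)on1`: > 128000 nM

All three share the same core and differ only in the ring at the far end. In an ADME assay on Vero cells (Chlorocebus sabaeus) for cytotoxicity, with a stated time of 72 h (on this read-out lower numbers stand for stronger inhibition and higher numbers for weaker inhibition), compound 1 gives 101000 nM. For compound 2 the read-out is not a number but a limit of the assay, > 128000 nM. For compound 3 the read-out is likewise a limit, > 128000 nM. Compound 2 thus stands at the limit of > 128000 nM in this assay, at which 2 of the 3 values shown sit, so only a floor is known for it, not a figure.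

Compound 4, `CCOC(=O)c1cc(-c2cccc(OCc3cc(F)ccc3F)c2)on1`, has not yet been measured. It differs from compound 2 in one place: 2,5-difluorophenyl in place of 3-methoxyphenyl on a saturated chain carbon bound to an oxygen on an aromatic ring.

For the measured compounds named here, the one measured step that touches the same far ring is an at least 1.2-fold higher number from compound 1 to compound 2 (0.10 log units; that floor lies within the scatter). That step swapped one group on that ring and moved the number by an amount that does not rise above the ordinary scatter. Going by the values given here, the change to compound 4 again alters only that ring, so for compound 4 the expected step is an at least 1.0-fold lower number from compound 2 to compound 4 (0.02 log units; that floor lies within the scatter), with no clear movement in either direction beyond the scatter. The estimate for compound 4 is therefore 120000 nM, with a range from 60000 nM to 250000 nM, and a good chance that only a limit is reported again.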

Compound 4, half-maximal inhibitory concentration: > 128000 nM
Compound 4 was reported as a limit; the forecaster's own chance of this, stated with the estimate: 60%; at least 1.0-fold (0.02 log units) between middle value and limit.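

In this assay compound 4 gives > 128000 nM, which is a limit and not a number. Compound 2 also stands at a limit, so no step can be read between compound 2 and compound 4: the limit of > 128000 nM in this assay, at which 3 of the 4 values shown sit.

The compounds shown leave open whether 2,5-difluorophenyl in place of 3-methoxyphenyl changes the read-out at all.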